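A Methoxyazetidine Amide Exchanged for a Free Acid

A few compounds are considered here, and "the series" means these few. Any claim that something is new, unique, unknown or untested is made for them only; others in the source may bear on it.

Measured so far:
compound 1 `COC1CN(C(=O)/C=C/c2ccncc2-c2ccc3ccccc3c2)C1`, in a functional assay on HCT-116 cells (Homo sapiens) for inhibition, read by MTT assay, with a stated time of 72 h; on this read-out lower numbers stand for stronger inhibition of growth and higher numbers for weaker inhibition of growth: > 30000 nM
compound 2 `Cn1ncc2cc(-c3cnccc3/C=C/C(=O)N3CCOCC3)ccc21`: "not determined" (no result reported)
compound 3 `CNC(=O)/C=C/c1ccncc1-c1ccc2cccnc2c1`: "not determined" (no result reported)

Among the measured compounds shown here, compound 1 is the only compound of the three with a result, and that result is a limit of the measurement, not a number. Where compound 1 stands is therefore described only by the limit of > 30000 nM in this assay, at which 1 of the 3 values shown sits; nothing finer than that is known. For the measured compounds named here, compound 2 and compound 3 carry no result at all, so no comparison between any two measured compounds can be drawn, and no step between measured compounds is available to lean on.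

Compound 4 `O=C(O)/C=C/c1ccncc1-c1ccc2ccccc2c1` keeps the shared core of compound 1 and alters a single spot: hydroxy in place of 3-methoxyazetidin-1-yl on a carbonyl carbon. Going by the values given here, with no measured step in hand, the size of the change from compound 1 to compound 4 has to be judged from the starting point alone. Since compound 1 sits at the limit (the limit of > 30000 nM in this assay, at which 1 of the 3 values shown sits), the step from compound 1 to compound 4 is expected to be none beyond the usual scatter, with compound 4 expected to remain at or near that limit, as a number no higher from compound 1 to compound 4 (the limit leaves the size open).

Compound 4 is thus estimated at 30000 nM, within a range from 10000 nM to 100000 nM, most likely reported once more only as a limit.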

Compound 4, concentration for 50% growth inhibition: > 30000 nM
Compound 4 was reported as a limit; the forecaster's own chance of this, stated with the estimate: 80%; the middle value lies on the limit itself.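

Compound 1 and compound 4 each give only a limit and not a number, so no step can be read from the exchange of 3-methoxyazetidin-1-yl for hydroxy: the limit of > 30000 nM in this assay, at which 2 of the 4 values shown sit. The compounds shown leave open what true number lies behind either limit in this assay, and whether any other group on that carbonyl carbon would give a readable value.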